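The source may hold more compounds than are shown below. What is called first, only, known or untested is meant among the compounds shown, and "the series" means these compounds.

Working notes on a series varied in one aromatic substituent on the shared core. In a functional assay on MCF7 cells (Homo sapiens) for inhibition, with a stated time of 72 h (on this read-out lower numbers stand for stronger inhibition and higher numbers for weaker inhibition), compound 1 (`NC1CCC(Nc2nc(NCc3ccc(-c4cccc(F)c4)cc3)c3ncn(C4CCCC4)c3n2)CC1`) gives 293 nM, compound 2 (`NC1CCC(Nc2nc(NCc3ccc(-c4ccco4)cc3)c3ncn(C4CCCC4)c3n2)CC1`) gives 85 nM and compound 3 (`NC1CCC(Nc2nc(NCc3ccc(-c4ccsc4)cc3)c3ncn(C4CCCC4)c3n2)CC1`) gives 145 nM. Compound 3 is second highest by rank only, with a 1.7-fold higher number from compound 2 to compound 3 (0.23 log units; within the scatter) and a 2.0-fold lower number from compound 1 to compound 3 (0.31 log units; beyond the scatter).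

Compound 4 (`NC1CCC(Nc2nc(NCc3ccc(-c4ccccc4O)cc3)c3ncn(C4CCCC4)c3n2)CC1`) has 2-hydroxyphenyl in place of thiophen-3-yl on an aromatic carbon.

Among the compounds with values here, two measured steps bear on this, a 3.4-fold lower number from compound 1 to compound 2 (0.54 log units; beyond the scatter) and a 2.0-fold lower number from compound 1 to compound 3 (0.31 log units; beyond the scatter). Both leave a six-membered aromatic ring for a five-membered one, and the change to compound 4 runs the other way. Within the data shown here, no measured compound carries a hydroxy group, so that part of the change is uncovered. In this assay a modest move to a higher number is expected, possibly no larger than the scatter. The estimated step is a 1.7-fold higher number from compound 3 to compound 4 (0.22 log units; within the scatter). The estimate for compound 4 is 240 nM, with an expected range from 90 nM to 600 nM.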

Compound 4, half-maximal inhibitory concentration: 2910 nM
For compound 4 the middle estimate is 12-fold (1.08 log units) below the measured one; measured number above the stated range.
By their numbers in this assay, from the lowest: compounds 2 and 3 (each within the scatter of the next); then compound 1; then compound 4.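

In this assay, within the data shown here, the aromatic substituent on this position proves far less forgiving than the earlier compounds showed: a 20-fold higher number from compound 3 to compound 4 (1.30 log units; beyond the scatter) and a 34-fold higher number from compound 2 to compound 4 (1.53 log units; beyond the scatter) are both large, whereas the steps among compound 1, compound 2 and compound 3 were no more than modest. Ring size alone does not cover the change, since 3-fluorophenyl is also a six-membered aromatic ring and there is still a 9.9-fold higher number from compound 1 to compound 4 (1.00 log units; beyond the scatter), which points to the 2-hydroxyphenyl, the only group here with a hydrogen-bond donor, as what sets compound 4 apart. No measured evidence on hand explains this loss.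

Open, from the compounds shown here alone, is whether the hydroxy group itself or its place on the ring carries the step, which a plain phenyl, a 2-methoxyphenyl or a 4-hydroxyphenyl would separate. A 2-aminophenyl would show whether another donor group behaves the same way.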